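The source may hold more compounds than are shown below. What is called first, only, known or untested is meant among the compounds shown, and "the series" means these compounds.

Compounds measured in an ADME assay on Vero cells (Chlorocebus sabaeus) for cytotoxicity, read by resazurin assay, with a stated time of 72 h; a higher number here means a weaker inhibitor, a lower number a stronger inhibitor:

- compound 1 `COc1ccc(C(=O)CCN2CCN(c3ccc(F)cc3)CC2)cc1` gives 55000 nM
- compound 2 `COc1ccc(C(=O)CCN2CCN(c3ccc(Cl)cc3)CC2)cc1` gives 300000 nM
- compound 3 `COc1ccc(C(=O)CCN2CCN(c3ccc([N+](=O)[O-])cc3)CC2)cc1` gives 587000 nM

On these numbers, compound 2 cannot be told apart from compound 3 (a 2.0-fold higher number from compound 2 to compound 3 (0.29 log units; within the scatter)). The gap on the other side is clear (a 5.5-fold higher number from compound 1 to compound 2 (0.74 log units; beyond the scatter)). The next compound to be tested, compound 4 `O=C(CCN1CCN(c2ccc(Cl)cc2)CC1)c1ccc(F)c(Cl)c1`, keeps the chloro substituent of compound 2 but carries 3-chloro-4-fluorophenyl in place of 4-methoxyphenyl on a carbonyl carbon.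

For the measured compounds named here, no measured step touches the group on the carbonyl carbon. All three swap a substituent on an aromatic carbon, so they bear on this change only indirectly. They do show that one such swap can move the number in this assay by a modest amount (a 5.5-fold higher number from compound 1 to compound 2 (0.74 log units; beyond the scatter)) or a large one (an 11-fold higher number from compound 1 to compound 3 (1.03 log units; beyond the scatter)). A whole-group exchange is therefore not expected to stay silent, though the data do not settle its direction. With compound 2 lying well clear of compound 1 (55000 nM), a modest move towards a lower number seems the likelier outcome. The expected size of the change is as follows (a 3.0-fold lower number from compound 2 to compound 4 (0.48 log units; beyond the scatter)). The estimate for compound 4 is 100000 nM, with an expected range from 25000 nM to 350000 nM.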

Compound 4, half-maximal inhibitory concentration: 114000 nM
Beside the measured number, compound 4's estimate is 1.1-fold (0.06 log units) below it, and the stated range covers the measured number.
By their numbers in this assay, from the lowest: compound 1; then compound 4; then compounds 2 and 3 (each within the scatter of the next).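

For the compounds shown here, compound 4 gives the first reading of a change on the carbonyl carbon: in this assay, exchanging 4-methoxyphenyl for 3-chloro-4-fluorophenyl produces a 2.6-fold lower number from compound 2 to compound 4 (0.42 log units; beyond the scatter) and shows that the number responds to the group at this position. The two groups have the same heavy-atom count and the same kind of aromatic ring, so this step does not come with a change in either; what differs is that the entering group carries fluorine and chlorine and the leaving group carries oxygen. Nothing shown accounts for the step.

The compounds shown leave open whether the fluorine, the chlorine or the loss of the methoxy group carries this step, and whether the same exchange would move the number similarly with the fluoro or nitro substituent of the other compounds in place of chloro. They also leave open how the number would respond on the carbonyl carbon to a plain phenyl group, or to a phenyl group bearing an amine or a carboxylic acid.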